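The source may report more compounds than this note shows. Statements on the series, on what has been measured and on what is new or still open speak of the compounds shown alone.

Measured in a functional assay on SEM cells (Homo sapiens) for cytotoxicity, with a stated time of 72 h; a higher number here means that more compound is needed for the effect, a lower number that less compound is needed:
- Compound 1 `C=C[C@@](C)(/C=C/c1ccc(O)c(CO)c1)CCC=C(C)C`: > 36600 nM, a limit
- Compound 2 `CCOc1ccc(/C=C/[C@@](C)(/C=C/c2ccc(O)cc2)CCC=C(C)C)cc1`: > 36600 nM, a limit

Compound 2 stands only at a limit, > 36600 nM, with no number behind it. Within the data shown here, the whole series so far reads as the limit of > 36600 nM in this assay, at which 2 of the 2 values shown sit.

Compound 3 `CC(C)=CCC[C@@](C)(/C=C/c1ccc(C)cc1)/C=C/c1ccc(O)cc1` carries methyl in place of ethoxy on an aromatic carbon, para to a large group: methyl in place of ethoxy on an aromatic carbon. Among the measured compounds shown here, no measured step shows what such a change does in this assay. Resting on (the limit of > 36600 nM in this assay, at which 2 of the 2 values shown sit), no shift beyond the scatter is expected, and another limit is likely. The expected change is an at least 1.2-fold lower number from compound 2 to compound 3 (0.08 log units; that floor lies within the scatter). For compound 3 the estimate is 30000 nM, with an expected range of 12000 nM to 60000 nM.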

Compound 3, half-maximal effective concentration: > 36600 nM
Compound 3: only a limit was reported (the forecaster's own chance of this, stated with the estimate: 70%); at least 1.2-fold (0.08 log units) between middle value and limit.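

Compound 2 and compound 3 both stand only at a limit, so no step can be read from methyl in place of ethoxy. The compounds shown leave open whether any change to this series would give a measurable value in this assay.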